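The source may hold more compounds than are shown below. What is called first, only, known or untested is meant among the compounds shown, and "the series" means these compounds.

Measured in a functional assay on HeLa cells (Homo sapiens) for cytotoxicity, read by MTT assay, with a stated time of 24 h; a higher number here means a weaker inhibitor, a lower number a stronger inhibitor:
compound 1 `COc1ccc(/C=C2\CN(C)C/C(=C\c3ccccc3F)C2=O)cc1OC`: 14400 nM
compound 2 `COc1cc(/C=C2\CN(C)C/C(=C\c3ccccc3F)C2=O)cc(OC)c1OC`: 3220 nM
compound 3 `CN1C/C(=C\c2ccc(C#N)cc2)C(=O)/C(=C/c2ccccc2F)C1`: 1340 nM

Compound 2 holds the second-highest number of the three, with compound 3 lower and compound 1 higher, and both gaps lie beyond the usual scatter. Compound 4 `COc1cc(/C=C2\CN(C)C/C(=C\c3ccc(F)cc3)C2=O)cc(OC)c1OC`, not yet measured, differs from compound 2 in one place: 4-fluorophenyl in place of 2-fluorophenyl on a double-bonded chain carbon bound to a double-bonded ring carbon. Among the compounds with values here, the only measured step, a 4.5-fold lower number from compound 1 to compound 2 (0.65 log units; beyond the scatter), is methoxy in place of hydrogen on an aromatic carbon, a different change at a different place, so it says little here. Within the data shown here, no measured step moves the fluorine. Accordingly, no step beyond the scatter is expected in this assay, in either direction. The expected step is a 1.1-fold lower number from compound 2 to compound 4 (0.03 log units; within the scatter). For compound 4 the estimated value is 3000 nM, with an expected range from 1100 nM to 8000 nM.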

Compound 4, half-maximal inhibitory concentration: 7250 nM
Beside the measured number, compound 4's estimate is 2.4-fold (0.38 log units) below it, within the range that was stated.
By their numbers in this assay, from the lowest: compound 3; then compound 2; then compounds 4 and 1 (each within the scatter of the next).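

In this assay, moving the fluorine alone counts: 4-fluorophenyl in place of 2-fluorophenyl on a double-bonded chain carbon bound to a double-bonded ring carbon gives a 2.3-fold higher number from compound 2 to compound 4 (0.35 log units; beyond the scatter), although the atoms stay the same. This place therefore responds to where the fluorine stands, which the earlier step, made elsewhere on the molecule, could not show. Nothing available explains this step.

As far as these compounds go, whether the fluorine is needed at all remains open, as does how a chlorophenyl or an aminophenyl group would read in this place. Also open, from the compounds shown here alone, is whether the same step would appear on the core of compound 1 or compound 3.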